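Shortening the chain of an iodoacetamide nucleotide

The compounds below may be only part of what the source reports. "The series", "measured", "known", "first", "only" and "open" are said of these compounds alone.

Going by the values given here, in an assay on isolated protein for inhibition of hexokinase-2 (Rattus norvegicus), with a stated time of 6 h, tested at 10 mM (a lower number here means less inhibition, a higher number more inhibition at the concentration tested (going by the name of the read-out)), compound 1 `O=C(CI)NCCCCCCCCNc1ncnc2c1ncn2[C@@H]1O[C@H](COP(=O)(O)OP(=O)(O)OP(=O)(O)O)[C@@H](O)[C@H]1O` gives 41%, the highest of the three numbers known. Compound 2 `CN(CCCN(C)C(=O)CCCCNc1ncnc2c1ncn2[C@@H]1O[C@H](COP(=O)(O)OP(=O)(O)OP(=O)(O)O)[C@@H](O)[C@H]1O)C(=O)CCCCNC(=O)CI` gives 0% and compound 3 `Nc1ncnc2c1nc(NCCNC(=O)CI)n2[C@@H]1O[C@H](COP(=O)(O)OP(=O)(O)OP(=O)(O)O)[C@@H](O)[C@H]1O` gives 0%, each lying below compound 1 by a gap beyond the scatter. Compound 4 `O=C(CI)NCCCCCCCNc1ncnc2c1ncn2[C@@H]1O[C@H](COP(=O)(O)OP(=O)(O)OP(=O)(O)O)[C@@H](O)[C@H]1O` is compound 1 altered in a single place: ((iodomethyl)carbonyl)amino in place of (((iodomethyl)carbonyl)amino)methyl on a saturated chain carbon, seven bonds along the chain from a nitrogen on an aromatic ring. Among the compounds with values here, no two measured compounds differ in one place alone, so no measured step guides this one. Since compound 2 sits at 0% and compound 3 at 0%, the shorter chain of compound 4 is expected to lose a little, though a change within the scatter would not surprise. The expected step is a number 11 percentage points lower from compound 1 to compound 4 (beyond the scatter). Compound 4 is therefore estimated at 30%, within 5% to 55%.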

Compound 4, a percentage reported as inhibition, at one concentration (the size of the read-out at that concentration, not a potency): 30%
The estimate for compound 4 equals the measured number at the digits printed, and the stated range covers the measured number.
By their numbers in this assay, from the lowest: compounds 2 and 3 (each within the scatter of the next); then compound 4; then compound 1.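

In this assay, going by these compounds alone, putting ((iodomethyl)carbonyl)amino in place of (((iodomethyl)carbonyl)amino)methyl at this chain carbon gives a number 11 percentage points lower from compound 1 to compound 4 (beyond the scatter), the first single change that can be read at this position. The number falls with the shorter chain, yet compound 4 keeps 30%, so this change lowers the reading without abolishing it. No measurement shown accounts for the size of this step.

The compounds shown leave open how a longer chain would read at this place. They also leave open whether an amine in place of the iodoacetamide end would retain any inhibition.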